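The source may report more compounds than this note shows. Statements on the series, on what has been measured and on what is new or still open speak of the compounds shown alone.

Among the measured compounds shown here, compound 1 `Cc1cc(Nc2nn(Cc3cc(F)ccc3F)c(=O)c3ccccc23)n[nH]1` is the one compound in this set with a number attached: in a functional assay on HCT-116 cells (Homo sapiens) for cytotoxicity, read by CellTiter-Glo, with a stated time of 5 days (a higher number here means a weaker inhibitor, a lower number a stronger inhibitor), compound 1 gives 570 nM. Compound 2 `CC(=O)Nc1ccc(Cn2nc(Nc3cc[nH]n3)c3ccccc3c2=O)cc1` gives in this assay only > 30000 nM, which is a limit of the assay and not a number. For the measured compounds named here, compound 1 therefore stands alone as the single measured value against which a new compound can be judged.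

Compound 3 `Cc1cc(Nc2nn(-c3ccc(F)cc3)c(=O)c3ccccc23)n[nH]1` has not yet been measured. It differs from compound 1 in one place: 4-fluorophenyl in place of 2,5-difluorobenzyl on an aromatic nitrogen. The group that enters is smaller by two heavy atoms and keeps one fluorine instead of two, and it sits on the aromatic nitrogen without the single carbon that linked the leaving group to that nitrogen.

Going by the values given here, no step between measured compounds shows how such a change plays out, so the expectation rests on the change alone. The expected step in this assay is a 3.5-fold higher number from compound 1 to compound 3 (0.55 log units; beyond the scatter), a loss of potency somewhat beyond the scatter. The estimate for compound 3 in this assay is 2000 nM, in a range from 500 nM to 10000 nM.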

Compound 3, half-maximal inhibitory concentration: 800 nM
Estimate against measurement, compound 3: 2.5-fold (0.40 log units) above, and the stated range covers the measured number.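

In this assay the swap of 2,5-difluorobenzyl for 4-fluorophenyl on the aromatic nitrogen gives a 1.4-fold higher number from compound 1 to compound 3 (0.15 log units; within the scatter), so the two compounds cannot be told apart in this read-out. Among the compounds shown here, this is the first sign that this position accepts more than one aromatic group: the ring can sit directly on the nitrogen, without the single carbon link and with one fluorine instead of two, and the cytotoxicity stays in the same range. Nothing shown here explains why the swap leaves the value within the scatter.

Compound 2 gives > 30000 nM, which is a limit of the assay and not a number, and it differs from compound 1 in more than one place, so it cannot show what any single group at this position does. The compounds shown also leave open whether the carbon link and the fluorines matter separately, which plain benzyl or unsubstituted phenyl could test, and whether this position would accept a longer chain such as 2-phenylethyl or a ring carrying an amine or a carboxylic acid.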